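The source may report more compounds than this note shows. Statements on the series, on what has been measured and on what is new or still open speak of the compounds shown alone.

Measured in a functional assay on MCF7 cells (Homo sapiens) for cytotoxicity, read by MTT assay, with a stated time of 72 h; a higher number here means a weaker inhibitor, a lower number a stronger inhibitor:

- compound 1 `CNC(=O)c1cc(Oc2ccc(C3=NNC(c4ccc(F)cc4Cl)C3)cc2)ccn1`: "not determined" (no result reported)
- compound 2 `CNC(=O)c1cc(Oc2ccc(C3=NNC(c4ccc([N+](=O)[O-])cc4)C3)cc2)ccn1`: "not determined" (no result reported)
- compound 3 `CNC(=O)c1cc(Oc2ccc(C3=NNC(c4cccc([N+](=O)[O-])c4)C3)cc2)ccn1`: 35400 nM

Compound 1 has no place on the numeric scale, since in this assay compound 1 stands at "not determined" (no result reported). The same holds for compound 2, which stands at "not determined" (no result reported). Going by the values given here, only compound 3 carries a number, 35400 nM, so no measured pair shows how a change of substituent moves the read-out.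

The next compound to be tested is compound 4 `CNC(=O)c1cc(Oc2ccc(C3=NNC(c4ccc(F)cc4)C3)cc2)ccn1`, which keeps the core of compound 1 and changes one substituent. The difference is hydrogen in place of chloro on an aromatic carbon. In other words, hydrogen takes the place of chloro on an aromatic carbon, and 2-chloro-4-fluorophenyl becomes 4-fluorophenyl.

Among the compounds with values here, with no measured step to go on, no shift beyond the scatter is expected in this assay, in either direction. This is a weak expectation, and the data offer no evidence on what losing the chloro does. Within the data shown here, the only numeric anchor is compound 3 at 35400 nM, so a value in the same region is expected, with a wide margin. In this assay compound 4 is estimated at 30000 nM, with an expected range from 10000 nM to 80000 nM.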

Compound 4, half-maximal inhibitory concentration: 9480 nM
Estimate against measurement, compound 4: 3.2-fold (0.50 log units) above; measured number outside the range, below it.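

In this assay, the series now gives its first readable step, a 3.7-fold lower number from compound 3 to compound 4 (0.57 log units; beyond the scatter), which shows that the aryl group on the saturated ring carbon can move the read-out beyond the scatter, with 4-fluorophenyl carrying the lower number and 3-nitrophenyl the higher. The change from 2-chloro-4-fluorophenyl to 4-fluorophenyl cannot be read, nor can any other step to compound 1 or compound 2, as neither of these two compounds has a reported result, so the effect of the chloro at this position remains unmeasured. No measurement on hand gives a reason for the step from the nitro-bearing compound to the fluoro-bearing one.

The step from compound 3 to compound 4 changes both the substituent and its place on the phenyl ring, so the compounds shown do not separate these two changes. They also leave open how a plain phenyl, or a phenyl bearing an amine or a carboxylic acid, would read in this assay on this same core.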